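From Fluorophenyl to Fluoropyridine on a Shared Core

The source may hold more compounds than are shown below. What is called first, only, known or untested is meant among the compounds shown, and "the series" means these compounds.

Of the compounds shown here, two sharing one core have been measured in a functional assay on THP-1 cells (Homo sapiens) for inhibition, read by ELISA, with stated times of 1 h and 18 h; a lower number here means a stronger inhibitor, a higher number a weaker inhibitor. Compound 1 `NC(=O)[C@@H]1[C@H](Nc2nc(Nc3cccc(C(=O)N4CCCC4)c3)ncc2C2CC2)[C@H]2C=C[C@@H]1C2`, which carries a cyclopropyl, gives 90 nM. Compound 2 `NC(=O)[C@@H]1[C@H](Nc2nc(Nc3cccc(C(=O)N4CCCC4)c3)ncc2-c2cccc(F)c2)[C@H]2C=C[C@@H]1C2`, which carries a 3-fluorophenyl on the same aromatic carbon, gives 870 nM, the higher number of the pair and so the weaker inhibitor. Compound 3 `NC(=O)[C@@H]1[C@H](Nc2nc(Nc3cccc(C(=O)N4CCCC4)c3)ncc2-c2cncc(F)c2)[C@H]2C=C[C@@H]1C2` keeps everything else and changes one group: 5-fluoropyridin-3-yl in place of 3-fluorophenyl on an aromatic carbon. That carbon belongs to a six-membered aromatic ring with 2 nitrogen. Going by the values given here, only one measured step touches this place, and it is a 9.7-fold higher number from compound 1 to compound 2 (0.99 log units; beyond the scatter). That step shows that the read-out in this assay responds to what stands here, but it exchanged a cyclopropyl for a whole aromatic ring, a larger swap than this one. Among the compounds with values here, no measured step shows what a single ring nitrogen does on its own, so no step beyond the usual scatter is expected in this assay. The estimated change is a 1.3-fold lower number from compound 2 to compound 3 (0.13 log units; within the scatter). For compound 3 the expected value is 650 nM, with a likely range from 220 nM to 1900 nM.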

Compound 3, half-maximal inhibitory concentration: 170 nM
For compound 3 the middle estimate is 3.8-fold (0.58 log units) above the measured one; measured number outside the range, below it.
By their numbers in this assay, from the lowest: compounds 1 and 3 (each within the scatter of the next); then compound 2.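

In this assay, the exchange of 3-fluorophenyl for 5-fluoropyridin-3-yl, two groups of equal heavy-atom count that differ by one ring nitrogen and one hydrogen-bond acceptor, gives a 5.1-fold lower number from compound 2 to compound 3 (0.71 log units; beyond the scatter) with nothing else changed, so this position responds to a single atom within the ring and not only to a swap of whole groups. The earlier step from cyclopropyl to 3-fluorophenyl, a 9.7-fold higher number from compound 1 to compound 2 (0.99 log units; beyond the scatter) in size, therefore did not show that any aromatic ring here carries that cost: the step with the new ring is a 1.9-fold higher number from compound 1 to compound 3 (0.28 log units; within the scatter) and stays within the scatter, so these two compounds cannot be told apart in this read-out. No accompanying measurement is available to explain what the ring nitrogen does here.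

The compounds shown leave open whether the fluorine contributes, which a pyridinyl ring without it would address. They also leave open how far this carbon tolerates quite different groups, such as an amine, a methoxy group or a longer alkyl chain, and whether any of these would match the numbers of the cyclopropyl and fluoropyridine compounds.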